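A few compounds are considered here, and "the series" means these few. Any claim that something is new, unique, unknown or untested is made for them only; others in the source may bear on it.

In an assay on isolated protein for inhibition of eIF-2-alpha kinase GCN2 (Homo sapiens) (on this read-out lower numbers stand for stronger inhibition and higher numbers for weaker inhibition), compound 3 `COCc1noc([C@@H]2CC[C@@H](Nc3ncc4c(Br)nn(-c5ccc6ncccc6c5)c4n3)C2)n1` gives 106 nM, the second highest of the three numbers available: compound 1 `CCn1cc(Nc2ncc3cnn(-c4ccc(OC)cc4)c3n2)cn1` gives 133 nM, which lies within the scatter of compound 3, while compound 2 `COCCNC(=O)[C@@H]1CC[C@@H](Nc2ncc3c(Br)nn(-c4ccc5ncccc5c4)c3n2)C1` gives 5 nM. Compound 4 `CNC(=O)[C@@H]1CC[C@@H](Nc2ncc3c(Br)nn(-c4ccc5ncccc5c4)c3n2)C1` differs from compound 3 in one place: a group of 4 heavy atoms (2 carbon, 1 nitrogen, 1 oxygen; no ring) in place of a group of 8 heavy atoms (4 carbon, 2 nitrogen, 2 oxygen; one five-membered aromatic ring with 3 hetero atoms), on a saturated ring carbon. Going by the values given here, one measured step bears on this change, a 21-fold higher number from compound 2 to compound 3 (1.33 log units; beyond the scatter), in which a chain amide on the same saturated ring carbon was exchanged for the same ring-containing group. Compound 4 undoes that exchange with a shorter amide, so a large step back down the numbers is expected, even though its amide is not identical to that of compound 2. Compound 4 is therefore expected to give 8 nM, between 3 nM and 25 nM, an estimated 13-fold lower number from compound 3 to compound 4 (1.12 log units; beyond the scatter).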

Compound 4, half-maximal inhibitory concentration: 21 nM
The estimate for compound 4 lay 2.6-fold (0.42 log units) below the measured number; the measured number falls inside the stated range.
By their numbers in this assay, from the lowest: compound 2; then compound 4; then compounds 3 and 1 (each within the scatter of the next).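

In this assay methylcarbamoyl in place of the group with the five-membered aromatic ring, on this saturated ring carbon, gives a 5.0-fold lower number from compound 3 to compound 4 (0.70 log units; beyond the scatter) and so shows that even the short amide improves on that ring group. The amide alone does not account for all of the earlier gain: hydrogen in place of methoxymethyl gives a 4.2-fold higher number from compound 2 to compound 4 (0.62 log units; beyond the scatter) and so shows that the chain on the amide nitrogen also counts. As far as these compounds go, whether a chain longer than methoxymethyl on that nitrogen, or a carboxylic acid on the ring carbon, would give a lower number stays open. Nothing at hand tells what lies behind these steps.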